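The compounds below may be only part of what the source reports. "The series", "measured", "known", "first", "only" and "open" are said of these compounds alone.

Compound 1 `CC1CCN(C2CCN(S(=O)(=O)c3cccnc3)CC2)CC1`: 2400 nM.
Compound 2 `CCc1ccc(S(=O)(=O)N2CCC(N3CCC(C)CC3)CC2)cc1`: > 5000 nM.

In a functional assay on DLD-1 cells (Homo sapiens) for antiproliferative activity, read by CellTiter-Glo, with a stated time of 72 h (on this read-out lower numbers stand for stronger inhibition and higher numbers for weaker inhibition), compound 1 gives 2400 nM. For compound 2 the read-out of > 5000 nM is a limit of this assay and not a number (the limit of > 5000 nM in this assay, at which 1 of the 2 values shown sits). Within the data shown here, the only measured change at the sulfonyl sulfur is an at least 2.0-fold higher number from compound 1 to compound 2 (0.31 log units; beyond the scatter). Compound 3 `CC1CCN(C2CCN(S(=O)(=O)c3ccc(F)cc3F)CC2)CC1` carries 2,4-difluorophenyl in place of 4-ethylphenyl on a sulfonyl sulfur. That single step, starting from a limit, bears on it but gives no firm direction. Compound 3 is expected near 4500 nM, between 1500 nM and 15000 nM. The expected step of an at least 1.1-fold lower number from compound 2 to compound 3 (0.04 log units; that floor lies within the scatter) stays within the scatter.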

Compound 3, half-maximal inhibitory concentration: 102 nM
Compound 3: middle estimate off by 44-fold (1.64 log units), on the high side; the whole stated range lies above it.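

In this assay the group on the sulfonyl sulfur can move the read-out by a large margin, which shows in a 24-fold lower number from compound 1 to compound 3 (1.37 log units; beyond the scatter) with 2,4-difluorophenyl replacing pyridin-3-yl. With 2,4-difluorophenyl replacing 4-ethylphenyl, the change is an at least 49-fold lower number from compound 2 to compound 3 (1.69 log units; beyond the scatter), so this size is a floor. Compound 2 stands at a limit of the assay and not at a number: the limit of > 5000 nM in this assay, at which 1 of the 3 values shown sits.

Whether both fluorines are needed remains open, since a phenyl group carrying a single fluorine is not among these compounds. On these data alone, how chlorine, an amine or a carboxylic acid on the phenyl ring would read also remains open.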